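This account rests on a few compounds, and the source may have more. Where it says the series, first, only, none or still open, it means among the compounds named here.

Measured so far in a functional assay on SK-MEL-5 cells (Homo sapiens) for inhibition, read by sulforhodamine B assay, with a stated time of 48 h; a lower number here means a stronger inhibitor, a higher number a weaker inhibitor:
- compound 1 `CN1CCCN(CCNc2nccc(-c3c(-c4cccc(O)c4)nc4sccn34)n2)S1(=O)=O`: 348 nM
- compound 2 `O=S(=O)(NCCCNc1nccc(-c2c(-c3cccc(O)c3)nc3sccn23)n1)c1cccc(F)c1`: 1060 nM

Not yet measured: compound 3 `O=S(=O)(NCCNc1nccc(-c2c(-c3cccc(O)c3)nc3sccn23)n1)c1ccc(F)cc1`.

Of the two measured compounds, compound 2 has the higher number, at 1060 nM. The next change is ((4-fluorophenyl)sulfonyl)amino in place of (((3-fluorophenyl)sulfonyl)amino)methyl on a saturated chain carbon, two bonds along the chain from a nitrogen on an aromatic ring, with ((4-fluorophenyl)sulfonyl)amino in place of (((3-fluorophenyl)sulfonyl)amino)methyl. Among the measured compounds shown here, the one measured step at this place, a 3.0-fold higher number from compound 1 to compound 2 (0.48 log units; beyond the scatter), is modest and swaps a very different group. For the measured compounds named here, no measured pair isolates the present change, so only a small shift is expected. In this assay the expected step is a 1.3-fold lower number from compound 2 to compound 3 (0.12 log units; within the scatter), slightly downward and not expected to exceed the scatter. The estimate for compound 3 is 800 nM, with an expected range of 300 nM to 2200 nM.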

Compound 3, half-maximal inhibitory concentration: 1610 nM
Compound 3: the middle estimate sits 2.0-fold (0.30 log units) below what was measured; the measured number falls inside the stated range.
By their numbers in this assay, from the lowest: compound 1; then compounds 2 and 3 (each within the scatter of the next).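

With ((4-fluorophenyl)sulfonyl)amino in place of (((3-fluorophenyl)sulfonyl)amino)methyl, this assay shows a 1.5-fold higher number from compound 2 to compound 3 (0.18 log units; within the scatter) and so does not separate these two groups at this place. Against the group in compound 1, the ((4-fluorophenyl)sulfonyl)amino group gives a 4.6-fold higher number from compound 1 to compound 3 (0.67 log units; beyond the scatter) and joins the earlier step of a 3.0-fold higher number from compound 1 to compound 2 (0.48 log units; beyond the scatter) in leaving compound 1 with the lowest number. No measurement here bears on the cause of these steps.

The step from compound 2 changes the chain and the fluorine position together, so neither change is isolated. On these data alone, how an amine or a carboxylic acid would behave at this place remains open.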